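Removing a Drawn Configuration From a Stable Amide

The compounds below may be only part of what the source reports. "The series", "measured", "known", "first", "only" and "open" are said of these compounds alone.

Compound 1, `Nc1ncc(-c2ccc(C(=O)N3CCC(O)CC3)cc2)nc1-c1ccc(C(F)(F)F)cc1`, sets the starting point in an ADME assay on microsomes from liver (Rattus norvegicus) for metabolic stability, read by LC-MS, using NADPH, with a stated time of 30 min, tested at 0.1 uM, in the presence of a further agent that is not named here; on this read-out lower numbers stand for a less stable compound and higher numbers for a more stable compound. In this assay compound 1 gives > 90%, which is a limit of the assay and not a number. Compound 2, `Nc1ncc(-c2ccc(C(=O)N3CC[C@H](O)C3)cc2)nc1-c1ccc(C(F)(F)F)cc1`, carries a 3-hydroxypyrrolidin-1-yl in place of the 4-hydroxypiperidin-1-yl on the carbonyl carbon. In this assay compound 2 gives > 90%, again a limit rather than a number. The step that the two limits leave unreadable from compound 1 to compound 2 cannot be sized because both values sit at the limit of > 90% in this assay, at which 2 of the 2 values shown sit. So compound 2 stands at the same limit as the only other compound measured, and nothing in the numbers separates the two.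

Compound 3, `Nc1ncc(-c2ccc(C(=O)N3CCC(O)C3)cc2)nc1-c1ccc(C(F)(F)F)cc1`, is the compound still to be measured. Compared with compound 2 it differs as follows: the two compounds have the same atoms and bonds; at least one stereo element is drawn with a configuration in one of them and without one in the other: 1 of 1 stereo elements differ; a stereocentre at a saturated ring carbon is drawn S in compound 2 and without a configuration in compound 3. For the measured compounds named here, the one measured step concerns a different change and is unreadable in size, so it gives no guide of its own for this step. With the atoms and bonds unchanged, the step that the limit leaves unreadable from compound 2 to compound 3 is expected to stay within the usual scatter. Compound 3 is therefore estimated to give about 93%, with a range from 85% to 100%.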

Compound 3, percent of the compound remaining: > 90%
Compound 3 was reported as a limit (the forecaster's own chance of this, stated with the estimate: 80%); the middle value does not contradict the limit.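

No step can be read from compound 2 to compound 3, or from compound 1 to compound 3, because all three compounds stand at the same limit, which is not a number: the limit of > 90% in this assay, at which 3 of the 3 values shown sit.

The compounds shown leave open how far apart the three stand in this assay and whether the configuration drawn in compound 2 makes any difference there.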